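Pyridin-3-yl Sulfonamide in a Chemokine Receptor Binding Series

The source may hold more compounds than are shown below. What is called first, only, known or untested is meant among the compounds shown, and "the series" means these compounds.

Compound 1 `O=C(NCc1ccc(CNS(=O)(=O)c2ccc(Cl)cc2)cc1)c1ccc(F)cc1` and compound 2 `Cc1ccccc1S(=O)(=O)NCc1ccc(CNC(=O)c2ccc(F)cc2)cc1` share one core and differ only at the sulfonyl sulfur. In an assay on MDA-MB-231 cells for binding affinity to C-X-C chemokine receptor type 4 (Homo sapiens), read by fluorescence and microscopy, with stated times of 10 min and 30 min (on this read-out lower numbers stand for an effect already at smaller amounts and higher numbers for an effect only at larger amounts of compound), compound 1 gives 100 nM, and compound 2 gives 100 nM; the step of no change at the digits printed from compound 1 to compound 2 (within the scatter) shows that one aryl group for another at this sulfur changed nothing beyond the scatter. Compound 3 `O=C(NCc1ccc(CNS(=O)(=O)c2cccnc2)cc1)c1ccc(F)cc1` carries the change (pyridin-3-yl in place of 2-methylphenyl on a sulfonyl sulfur). For the measured compounds named here, only that single step bears on this position, and it lay within the scatter, so for compound 3 a step of no change at the digits printed from compound 2 to compound 3 (within the scatter) is expected, none beyond the scatter. Compound 3 is therefore estimated at 100 nM, within 40 nM to 250 nM.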

Compound 3, effective concentration (reported as EC, without a stated level of effect): 1000 nM
Beside the measured number, compound 3's estimate is 10-fold (1.00 log units) below it; measured number above the stated range.
By their numbers in this assay, from the lowest: compounds 1 and 2 (each within the scatter of the next); then compound 3.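

In this assay, the group on the sulfonyl sulfur now matters: pyridin-3-yl brought a 10-fold higher number from compound 2 to compound 3 (1.00 log units; beyond the scatter) and a 10-fold higher number from compound 1 to compound 3 (1.00 log units; beyond the scatter), although 2-methylphenyl and 4-chlorophenyl had given the same number. Among these three compounds, the two rings of carbon only stand level, and the one ring with a hetero atom stands apart. No measurement at hand accounts for this difference.

The compounds shown leave open whether pyridin-4-yl or a phenyl ring carrying an amine would also give a higher number on this sulfur. They also leave open how a plain ethyl chain would compare with these aromatic rings.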